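Swapping fluoro for methyl on an inactive bromophenol

The compounds below may be only part of what the source reports. "The series", "measured", "known", "first", "only" and "open" are said of these compounds alone.

The shared core carries a phenyl ring on a triazole arm, and the measured compounds all bear a substituent on that ring. Compound 1 (`C=C1C[C@]23C[C@@]1(O)CC[C@H]2c1cc(Br)c(O)c(C)c1[C@@H]3Cn1cc(-c2ccc(F)cc2)nn1`) gives > 20000 nM in a functional assay on SMMC-7721 cells (Homo sapiens) for cytotoxicity, read by MTT assay, with a stated time of 4 days (on this read-out higher numbers stand for weaker inhibition and lower numbers for stronger inhibition), which is a limit of the assay rather than a number. Compound 2 (`C=C1C[C@]23C[C@@]1(O)CC[C@H]2c1ccc(O)c(C)c1[C@@H]3Cn1cc(-c2ccc(F)cc2)nn1`) also gives > 20000 nM, again only a limit. Compound 3 (`C=C1C(=O)[C@]23C[C@@]1(O)CC[C@H]2c1ccc(OS(=O)(=O)c2ccc(C)cc2)c(C)c1[C@@H]3Cn1cc(-c2ccc(OC)cc2)nn1`), which differs from both in several places at once, gives 1720 nM. For the measured compounds named here, the only single-change step measured, a step that the two limits leave unreadable from compound 1 to compound 2, cannot be sized because both of its values sit at the limit of > 20000 nM in this assay, at which 2 of the 3 values shown sit.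

Compound 4 (`C=C1C[C@]23C[C@@]1(O)CC[C@H]2c1cc(Br)c(O)c(C)c1[C@@H]3Cn1cc(-c2ccc(C)cc2)nn1`) is made from compound 1 by methyl in place of fluoro on an aromatic carbon. Going by the values given here, no measured step touches this phenyl substituent, so the expectation rests only on where compound 1 stands, at a limit. Compound 4 is therefore expected to give 25000 nM, within a range from 8000 nM to 100000 nM. The step that the limit leaves unreadable from compound 1 to compound 4 is estimated to lie within the scatter, most likely again reported as a limit.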

Compound 4, half-maximal inhibitory concentration: > 20000 nM
Compound 4: only a limit was reported; the forecaster's own chance of this, stated with the estimate: 80%; the middle value is on the limit's open side.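

For the compounds shown here, compound 1 and compound 4 are both reported only as limits, not as numbers, and no step between them can be read. Left open is whether 4-fluorophenyl and 4-methylphenyl differ at all in this assay on this core, which remains hidden at the limit: the limit of > 20000 nM in this assay, at which 3 of the 4 values shown sit.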